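This account rests on a few compounds, and the source may have more. Where it says the series, first, only, none or still open, it means among the compounds named here.

Measured so far:
compound 1 `CC1CCN(c2c(S(=O)(=O)c3cc(Cl)cc(Cl)c3)cnc3ccc(Cl)cc23)CC1` — 88%
compound 2 `Cc1ccc2ncc(S(=O)(=O)c3cc(Cl)cc(Cl)c3)c(N3CCC(C)CC3)c2c1` — 75%

Both measured compounds carry a 3,5-dichlorophenyl on the sulfonyl sulfur and differ only on the shared core. In an assay on isolated protein for displacement of a labelled ligand from metabotropic glutamate receptor 5 (Homo sapiens), with a stated time of 60 min, tested at 1 uM (on this read-out higher numbers stand for more inhibition at the one concentration tested (going by the name of the read-out) and lower numbers for less inhibition), compound 1 gives 88% and stands highest of the two numbers. Compound 2 is nearest, with a number 13 percentage points lower from compound 1 to compound 2 (beyond the scatter). Going by the values given here, that single step, methyl in place of chloro on an aromatic carbon, is the only comparison available.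

Compound 3 `CC1CCN(c2c(S(=O)(=O)c3cccc(F)c3)cnc3ccc(Cl)cc23)CC1` differs from compound 1 at another place: 3-fluorophenyl in place of 3,5-dichlorophenyl on a sulfonyl sulfur. Among the compounds with values here, no measured step touches the group on the sulfonyl sulfur, so the step from compound 1 to compound 2 bears on it only indirectly, in showing that a one-place change elsewhere moved the read-out by a modest amount beyond the scatter. The change to compound 3 exchanges the whole ring on the sulfonyl sulfur, a larger alteration than the one measured, and the direction is not fixed by any shown number. The expectation is a decrease beyond the scatter, with wide uncertainty. For compound 3 the estimated value in this assay is 60% (range 25% to 88%), which is expected to amount to a number 28 percentage points lower from compound 1 to compound 3 (beyond the scatter).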

Compound 3, a percentage reported as inhibition, at one concentration (the size of the read-out at that concentration, not a potency): 58%
For compound 3 the middle estimate is 2 percentage points above the measured one; measured number inside the range.
By their numbers in this assay, from the lowest: compound 3; then compound 2; then compound 1.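

In this assay the group on the sulfonyl sulfur now has a measured one-place change of its own: with the rest of the structure held, 3-fluorophenyl in place of 3,5-dichlorophenyl gives a number 30 percentage points lower from compound 1 to compound 3 (beyond the scatter), so this position is sensitive to what the ring carries. The ring itself stays a six-membered aromatic ring of carbon only, and the change lies in its substituents: two chlorine atoms leave and one fluorine enters in a single step, so the loss of chlorine and the arrival of fluorine cannot be told apart. No measurement at hand gives a reason for this drop.

Open, from the compounds shown here alone, is how the read-out behaves at this position with intermediate or different groups on the sulfonyl sulfur, such as unsubstituted phenyl, a phenyl with a single chlorine, 3,5-difluorophenyl or a pyridyl ring, any of which would help separate the two parts of the change. Also open, going by these compounds, is whether 3-fluorophenyl gives a step of similar size on the methyl-bearing core of compound 2 , since only the chloro-bearing core has been seen with both groups here.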